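The source may report more compounds than this note shows. Statements on the series, on what has been measured and on what is new or still open speak of the compounds shown alone.

Working notes on the series.

Three measured members share one core. Compound 1 `COc1ccccc1N1CCN(CCCOc2ccc(C(=O)Nc3ccccc3OCCCC(=O)O)cc2)CC1` gives 41000 nM in an assay on isolated protein for inhibition of steroid 5-alpha-reductase (Rattus norvegicus); on this read-out higher numbers stand for weaker inhibition and lower numbers for stronger inhibition. Compound 2 `COc1ccccc1N1CCN(CCCCOc2ccc(C(=O)Nc3ccccc3OCCCC(=O)O)cc2)CC1` gives 43000 nM in this assay, and compound 3 `COc1ccccc1N1CCN(CCCCCCOc2ccc(C(=O)Nc3ccccc3OCCCC(=O)O)cc2)CC1` gives 9500 nM. Compound 1 therefore stands second highest of the three numbers: compound 2 lies within the scatter of it, so no order between the two is claimed, while compound 3 sits beyond the scatter below both, the only clear separation in the set. The three differ from one another only in the length of the chain joining the piperazine to the aromatic oxygen.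

The next step starts from compound 1 and leads to compound 4 `COc1ccccc1N1CCN(CCC(Oc2ccc(C(=O)Nc3ccccc3OCCCC(=O)O)cc2)c2cccc(C)c2)CC1`. The change is 3-methylphenyl in place of hydrogen on a saturated chain carbon bound to an oxygen on an aromatic ring and a saturated chain carbon. Within the data shown here, no measured pair in the set carries this change, so no measured step exists for it; what is known is that the only variation measured so far, the chain length between compound 1 and compound 3, moved the number clearly, which shows the region near that chain is not indifferent. A step of modest size toward stronger inhibition is expected, though one within or only just beyond the scatter is plausible. For compound 4 the expected step of a 2.1-fold lower number from compound 1 to compound 4 (0.31 log units; beyond the scatter) gives an estimate of 20000 nM, with a range from 5000 nM to 80000 nM.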

Compound 4, half-maximal inhibitory concentration: 360 nM
Beside the measured number, compound 4's estimate is 56-fold (1.74 log units) above it, outside the stated range (below it).
By their numbers in this assay, from the lowest: compound 4; then compound 3; then compounds 1 and 2 (each within the scatter of the next).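

In this assay, the carbon bound to an oxygen on an aromatic ring and a saturated chain carbon proves to be a highly responsive place in the series: 3-methylphenyl in place of hydrogen gives a 110-fold lower number from compound 1 to compound 4 (2.06 log units; beyond the scatter), a large step toward stronger inhibition. Compounds 1, 2 and 3 varied only the chain length and could say nothing about substitution on this carbon, whereas the new result shows that it accepts a group of 7 heavy atoms, with one six-membered aromatic ring of carbon only, and that inhibition strengthens rather than being lost. No supporting data at hand bear on what lies behind the size of this step.

The compounds shown leave open whether the step belongs to the aromatic ring or needs its methyl, a question that an unsubstituted phenyl, or a methyl alone on this carbon, would help to separate. They also leave open whether 3-methylphenyl on this carbon would combine with the longer hexyl-type chain of compound 3, or whether a chlorine or a methoxy on the new ring would hold the gain.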